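The source may report more compounds than this note shows. Statements on the series, on what has been measured and on what is new or still open speak of the compounds shown alone.

In a functional assay on HeLa cells (Homo sapiens) for cytotoxicity, read by MTT assay (a higher number here means a weaker inhibitor, a lower number a stronger inhibitor), three compounds have been measured so far:

- compound 1 `CC(C)=CC[C@@H](OCC(C)O)C1=CC(=O)c2c(O)ccc(O)c2C1=O`: 24700 nM
- compound 2 `CCCC(C)(O)CC(=O)O[C@H](CC=C(C)C)C1=CC(=O)c2c(O)ccc(O)c2C1=O`: 72000 nM
- compound 3 `CC(C)=CC[C@@H](OCCO)C1=CC(=O)c2c(O)ccc(O)c2C1=O`: 18600 nM

Compound 3 and compound 1 cannot be told apart, with a 1.3-fold lower number from compound 1 to compound 3 (0.12 log units; within the scatter). Compound 2 stands clearly apart, with a 3.9-fold lower number from compound 2 to compound 3 (0.59 log units; beyond the scatter).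

The next compound is compound 4 `CCC(O)(CC)CC(=O)O[C@H](CC=C(C)C)C1=CC(=O)c2c(O)ccc(O)c2C1=O`. It carries (2-ethyl-2-hydroxybutyl)carbonyl in place of 2-hydroxyethyl on an oxygen on a saturated carbon.

Among the compounds with values here, the closest precedent is the exchange between compound 2 and compound 3, which runs the opposite way and involves (2-hydroxy-2-methylpentyl)carbonyl. Read in reverse, it suggests that a carbonyl group of this kind raises the number. The step of a 2.9-fold higher number from compound 1 to compound 2 (0.46 log units; beyond the scatter) points the same way and is of similar modest size. Within the data shown here, both steps rest on compound 2 alone, so this is a thin basis, and no measured compound yet carries the group found in compound 4.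

A modest move towards weaker inhibition in this assay is therefore expected, and the estimated change is a 3.2-fold higher number from compound 3 to compound 4 (0.51 log units; beyond the scatter). For compound 4 the estimate is 60000 nM, with an expected range from 26000 nM to 130000 nM.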

Compound 4, half-maximal inhibitory concentration: 52000 nM
Compound 4: the middle estimate sits 1.2-fold (0.06 log units) above what was measured; the range from low to high includes it.
By their numbers in this assay, from the lowest: compounds 3 and 1 (each within the scatter of the next); then compounds 4 and 2 (each within the scatter of the next).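

In this assay, the higher number seen with compound 2 now has a second example at this position, on an oxygen on a saturated carbon: putting (2-ethyl-2-hydroxybutyl)carbonyl in place of 2-hydroxyethyl gives a 2.8-fold higher number from compound 3 to compound 4 (0.45 log units; beyond the scatter) and putting it in place of 2-hydroxypropyl gives a 2.1-fold higher number from compound 1 to compound 4 (0.32 log units; beyond the scatter) in the same direction, so the pattern no longer rests on compound 2 alone, and none of the four compounds goes against it. The branching of the chain end makes no readable difference here, since 1-ethyl-1-hydroxypropyl in place of 1-hydroxy-1-methylbutyl gives a 1.4-fold lower number from compound 2 to compound 4 (0.14 log units; within the scatter) and stays within the scatter. Nothing available explains why the two carbonyl-bearing groups give higher numbers than the two hydroxyalkyl groups.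

The compounds shown leave open whether the carbonyl or the hydroxyl of these side chains carries the shift, as a plain acetyl group or a longer chain without a hydroxyl would test that. They also leave open how an amine or a carboxylic acid at this oxygen would read, and whether methoxy groups in place of the hydroxyls on the shared core would change the picture.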